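The source may hold more compounds than are shown below. What is called first, only, known or untested is meant among the compounds shown, and "the series" means these compounds.

In a functional assay on A549 cells (Homo sapiens) for cytotoxicity, read by MTT assay, with a stated time of 72 h (a lower number here means a stronger inhibitor, a higher number a weaker inhibitor), compound 2 `C=C(C)[C@H]1CC[C@@](C)(O)[C@@H]1/C=C/C(C)=C/[C@@H]1C[C@@]23[C@H](OCCC[C@@H]2/C(=C(/C)C=O)CC[C@]3(C)O)O1` gives > 10000 nM, which is a limit of the assay and not a number. Compound 1 `C=C(C)[C@@H]1CC[C@](C)(O)[C@H]1/C=C/C(C)=C/[C@@H]1C[C@@]23[C@H](OCCC[C@@H]2/C(=C(/C)C=O)CC[C@]3(C)O)O1` gives > 10000 nM, which is also a limit. Neither compound therefore has a measured potency: the limit of > 10000 nM in this assay, at which 2 of the 2 values shown sit.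

Compound 3 `C=C(C)[C@H]1CC[C@@](C)(O)[C@@H]1/C=C/C(C)=C/[C@@H]1C[C@@]23[C@H](OCCC[C@@H]2/C(=C(\C)C=O)CC[C@]3(C)O)O1` keeps all the atoms and bonds of compound 2, and nothing leaves or enters: the two compounds have the same atoms and bonds and differ only in configuration as drawn: 1 of 11 stereo elements differ; a double bond is drawn Z in compound 2 and E in compound 3. Within the data shown here, the one measured step that bears on this is a step that the two limits leave unreadable from compound 1 to compound 2. Its size cannot be read, and it too is a change in configuration alone, as the fact that compounds 1 and 2 differ only in the configuration as drawn records. It offers no evidence that such a change moves the result. The expected size of the step that the limit leaves unreadable from compound 2 to compound 3 is nothing beyond the scatter, with no direction favoured, and another limit is the likeliest report. The estimate for compound 3 is 14000 nM, with an expected range from 6000 nM to 40000 nM.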

Compound 3, half-maximal inhibitory concentration: > 10000 nM
Compound 3 was reported as a limit; the forecaster's own chance of this, stated with the estimate: 85%; the middle value does not contradict the limit.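

Among these compounds, compound 3, like compound 1 and compound 2, is reported only as a limit and not a number, so no step among the three can be read: the limit of > 10000 nM in this assay, at which 3 of the 3 values shown sit.

From the compounds shown here alone, whether any of these changes in configuration alters potency remains open.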